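One chloro fewer: from compound 3 to compound 4

The source may report more compounds than this note shows. Statements on the series, on what has been measured and on what is new or still open speak of the compounds shown alone.

Whole-animal tests can be hard to read when a series offers few actual numbers, and this small set of compounds is such a case. In a functional assay on the whole organism with Mus musculus as the target (on this read-out lower numbers stand for an effect already at smaller amounts and higher numbers for an effect only at larger amounts of compound), compound 3 `Cn1nc(-c2ccc(Cl)cc2Cl)n(C)c1=S` gives > 25 mg/kg, which is a limit and not a number. Compound 1 `CCn1nc(-c2ccc(Cl)cc2)n(C)c1=S` gives > 50 mg/kg, also a limit. Compound 2 `Cn1nc(-c2ccccc2)n(C)c1=O` gives > 50 mg/kg, again a limit. Compound 3 therefore stands with the two others at a limit, and no measured number exists yet to anchor a comparison.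

Compound 4 `Cn1nc(-c2ccc(Cl)cc2)n(C)c1=S` differs from compound 3 in a single place: hydrogen in place of chloro on an aromatic carbon. In words, it carries hydrogen in place of chloro on an aromatic carbon. Within the data shown here, no measured pair in this set shows what such a swap does in this assay, so any forecast must stay loose. A modest shift toward a smaller dose seems a reasonable expectation, with a real chance that compound 4 also ends at a limit. The expected change is a number no higher from compound 3 to compound 4 (the limit leaves the size open). For compound 4 the estimated dose is 25 mg/kg, with an expected range from 8 mg/kg to 70 mg/kg.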

Compound 4, dose for half-maximal effect: 1.34 mg/kg
Compound 4: the middle estimate sits 19-fold (1.27 log units) above what was measured; measured number outside the range, below it.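

Among these compounds, compound 4 is the first compound here with a measured number instead of a limit, so the dichloro and monochloro forms can now be compared at this ring position. In this assay, hydrogen in place of the chloro on an aromatic carbon, ortho to a group of 8 heavy atoms and meta to a chloro group, gives an at least 18-fold lower number from compound 3 to compound 4 (1.27 log units; beyond the scatter), so the ring with only the remaining chloro group is tied to an effect at a far smaller dose. A change at a second place, hydrogen in place of methyl on a saturated chain carbon bound to an aromatic nitrogen, turns the ethyl group of compound 1 into a methyl group and gives an at least 37-fold lower number from compound 1 to compound 4 (1.57 log units; beyond the scatter), so that chain matters just as clearly, and the true size of the first step stays open because it starts from a limit: the limit of > 25 mg/kg in this assay, at which 1 of the 4 values shown sits.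

The second step is likewise only a lower bound because it also starts from a limit: the limit of > 50 mg/kg in this assay, at which 2 of the 4 values shown sit. The compounds shown also leave open what a fluoro or methoxy group at the chloro position, or a propyl chain on that nitrogen, would do.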